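This account rests on a few compounds, and the source may have more. Where it says the series, first, only, none or still open, it means among the compounds named here.

Going by the values given here, in a functional assay on HEK293 cells for agonist activity at G-protein coupled receptor 39 (Homo sapiens), read by scintillation proximity assay and inositol phosphate accumulation, with a stated time of 75 min, in the presence of a further agent that is not named here (a lower number here means that less compound is needed, a higher number that more compound is needed for the effect), compound 1 `Cc1nn(-c2ncnc3nc[nH]c23)c2c1C(OC1CCCC1)CC(=O)N2` gives 2 nM, the lowest of the three numbers measured so far. Compound 2 `Cc1nn(-c2ncnc3nc[nH]c23)c2c1C(C(=O)NCc1ccc(F)cc1)CC(=O)N2` gives 4 nM, which lies within the scatter of compound 1; compound 3 `C/C(=N\NC(=O)c1cc2ccccc2cc1O)c1ccc(N)cc1` gives 1100 nM, far beyond the scatter. Compound 4 `Cc1cc(C)n(CCOC2CC(=O)Nc3c2c(C)nn3-c2ncnc3nc[nH]c23)n1` is not yet measured and differs from compound 1 only by 2-(3,5-dimethyl-1H-pyrazol-1-yl)ethyl in place of cyclopentyl on an oxygen on a saturated carbon. Among the compounds with values here, no measured pair in this set isolates a change at this position, so the expectation rests on the shared core of compound 1 and compound 2, which both give low numbers while carrying different groups at the saturated carbon. The step of a 3.0-fold higher number from compound 1 to compound 4 (0.48 log units; beyond the scatter) is expected to be modest, toward a higher number, or none beyond the scatter. Compound 4 is estimated at 6 nM, within 1.5 nM to 25 nM.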

Compound 4, half-maximal effective concentration: 16 nM
The estimate for compound 4 lay 2.7-fold (0.43 log units) below the measured number, and the stated range covers the measured number.
By their numbers in this assay, from the lowest: compounds 1 and 2 (each within the scatter of the next); then compound 4; then compound 3.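

Replacing cyclopentyl with 2-(3,5-dimethyl-1H-pyrazol-1-yl)ethyl on the oxygen gives an 8.0-fold higher number from compound 1 to compound 4 (0.90 log units; beyond the scatter) in this assay, the first step read at this position. The position therefore responds to the group on the oxygen, yet the larger group with its aromatic ring still leaves compound 4 at 16 nM. No independent measurement bears on the reason for this step.

The compounds shown do not separate the contribution of the pyrazole ring from that of the ethyl chain. A plain ethyl group, or a longer chain ending in an amine or a carboxylic acid, would be needed to test this.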